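Triazole-linked dienones with a coumarin tail: growth inhibition notes

This account rests on a few compounds, and the source may have more. Where it says the series, first, only, none or still open, it means among the compounds named here.

Measured compounds:
compound 1 `COc1cc(/C=C/C(=O)/C=C/c2cccs2)ccc1OCc1cn(CCOc2cc(=O)oc3ccccc23)nn1`: 71%
compound 2 `COc1cc(/C=C/C(=O)/C=C/c2cc(OC)c(OC)c(OC)c2)ccc1OCc1cn(CCOc2cc(=O)oc3ccccc23)nn1`: 89%
compound 3 `COc1cc(/C=C/C(=O)/C=C/c2cc(OC)c(OC)c(OC)c2)ccc1OCc1cn(CCCOc2cc(=O)oc3ccccc23)nn1`: 76%

In a functional assay on HCT-116 cells (Homo sapiens) for inhibition, read by sulforhodamine B assay, with a stated time of 48 h, tested at 50 uM (on this read-out higher numbers stand for more inhibition of growth at the one concentration tested and lower numbers for less inhibition of growth), compound 2 gives 89%, compound 3 gives 76% and compound 1 gives 71%. Compound 3 and compound 1 lie within the scatter of each other; compound 2 stands beyond the scatter above both. The difference between the cores of compound 2 and compound 3 is not broken down here.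

One change is seen twice. From compound 2 to compound 1 it is thiophen-2-yl in place of 3,4,5-trimethoxyphenyl on a double-bonded chain carbon bound to a double-bonded chain carbon, and it gave a number 18 percentage points lower from compound 2 to compound 1 (beyond the scatter). The same change, (thiophen-2-yl in place of 3,4,5-trimethoxyphenyl on a double-bonded chain carbon bound to a double-bonded chain carbon), leads from compound 3 to the unmeasured compound 4 `COc1cc(/C=C/C(=O)/C=C/c2cccs2)ccc1OCc1cn(CCCOc2cc(=O)oc3ccccc23)nn1`; the place is the same word for word in both cases.

Among the compounds with values here, a step of similar size is expected from compound 3 to compound 4 in this assay, about a number 18 percentage points lower from compound 3 to compound 4 (beyond the scatter), because the earlier step of a number 18 percentage points lower from compound 2 to compound 1 (beyond the scatter) is the only precedent. Compound 4 is therefore estimated at 58%, expected between 42% and 72%.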

Compound 4, percent growth inhibition at one concentration: 58%
Beside the measured number, compound 4's estimate shows no gap at the digits printed; the range from low to high includes it.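

In this assay, thiophen-2-yl in place of 3,4,5-trimethoxyphenyl gave a number 18 percentage points lower from compound 3 to compound 4 (beyond the scatter). Set beside the earlier step, the change keeps its size from one core to the other: the same change on two cores in this assay, a number 18 percentage points lower (beyond the scatter) from compound 2 to compound 1 and a number 18 percentage points lower (beyond the scatter) from compound 3 to compound 4, 0 percentage points apart, within the scatter of two such steps This covers only these two cores, one cell line and one concentration, so it gives neither a rule for other cores nor a reason for the step.

Still open, from the compounds shown here alone, is whether furan-2-yl or an unsubstituted phenyl on a double-bonded chain carbon bound to a double-bonded chain carbon would give a step of the same size. Also open, going by these compounds, is whether the step would hold on a core with a longer chain.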